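A chloro group on compound 3: what to expect

The source may hold more compounds than are shown below. What is called first, only, known or untested is meant among the compounds shown, and "the series" means these compounds.

Measured so far in an ADME assay on HEK293 cells (Homo sapiens) for cytotoxicity, read by MTT assay, with a stated time of 48 h; a lower number here means a stronger inhibitor, a higher number a weaker inhibitor:
compound 1 `N#Cc1nc2c(-c3nc4ccccc4[nH]3)c(N)n(CCN3CCCC3)c2nc1C#N` gives 18300 nM
compound 2 `CN(C)CCCn1c(N)c(-c2nc3ccccc3[nH]2)c2nc(C#N)c(C#N)nc21` gives 8360 nM
compound 3 `CCN(CC)CCCn1c(N)c(-c2nc3ccccc3[nH]2)c2nc(C#N)c(C#N)nc21` gives 7870 nM

Compound 3 stands with its nearest neighbour, the gap being a 1.1-fold lower number from compound 2 to compound 3 (0.03 log units; within the scatter) and so within the scatter. Its gap to the furthest is a 2.3-fold lower number from compound 1 to compound 3 (0.37 log units; beyond the scatter) and lies beyond the scatter.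

Compound 4 `CCN(CC)CCCn1c(N)c(-c2nc3cc(Cl)ccc3[nH]2)c2nc(C#N)c(C#N)nc21` has chloro in place of hydrogen on an aromatic carbon, which turns 1H-benzimidazol-2-yl into 5-chloro-1H-benzimidazol-2-yl. Its counted difference from compound 3 is chloro in place of hydrogen on an aromatic carbon and nothing else changes.

Going by the values given here, none of the measured steps involves this kind of change, since all three lie on the saturated chain. They can serve only as a rough guide to size. The larger ones, a 2.2-fold lower number from compound 1 to compound 2 (0.34 log units; beyond the scatter) and the gap already given for compound 3, are modest. Among the compounds with values here, with no measured example of chloro on the shared core, only a small step is expected, leaning toward a lower number without any firm ground for passing the scatter. The expected step is a 1.3-fold lower number from compound 3 to compound 4 (0.12 log units; within the scatter) in this assay on this reasoning. Compound 4 is estimated at 6000 nM with an expected range from 2500 nM to 14000 nM for its measurement.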

Compound 4, half-maximal inhibitory concentration: 8420 nM
Estimate against measurement, compound 4: 1.4-fold (0.15 log units) below; measured number inside the range.
By their numbers in this assay, from the lowest: compounds 3, 2 and 4 (each within the scatter of the next); then compound 1.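

In this assay, chloro in place of hydrogen on an aromatic carbon, which turns 1H-benzimidazol-2-yl into 5-chloro-1H-benzimidazol-2-yl, gives a 1.1-fold higher number from compound 3 to compound 4 (0.03 log units; within the scatter), so compound 3 and compound 4 cannot be told apart in this read-out. This is the first change shown on the six-membered aromatic ring of carbon only, as all the earlier steps lay on the saturated chain, and here a single added chlorine on the shared core leaves the number where the scatter cannot separate it from that of compound 3. Nothing available bears on why this change has so little effect here.

As far as these compounds go, it remains open whether a different group at this same place, such as fluoro, methoxy or an amine, would give a step beyond the scatter in this assay. It is equally open whether chloro would behave the same way on the shared core when it carries the pyrrolidin-1-yl side chain of compound 1 or the dimethylamino side chain of compound 2, since the one step shown has the diethylamino side chain throughout.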